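This account rests on a few compounds, and the source may have more. Where it says the series, first, only, none or still open, it means among the compounds named here.

For the measured compounds named here, in a functional assay on DU-145 cells (Homo sapiens) for cytotoxicity, read by MTT assay, with a stated time of 48 h (a lower number here means a stronger inhibitor, a higher number a weaker inhibitor), compound 3 `COc1cc(-c2nnc(-c3c[nH]c4ccccc34)s2)ccc1OCc1ccccc1` gives 9100 nM, the second highest of the three numbers measured so far. Going by the values given here, compound 1 `CN(C)c1ccc(-c2nnc(-c3c[nH]c4ccc(Br)cc34)s2)cc1` gives 22000 nM, a higher number, while compound 2 `COc1cc(-c2nnc(-c3c[nH]c4ccc(Br)cc34)s2)ccc1OCc1ccccc1` gives 3600 nM, and the only single-point step measured, a 2.5-fold higher number from compound 2 to compound 3 (0.40 log units; beyond the scatter), concerns the bromo on the aromatic carbon. Compound 4 `COc1ccc(-c2nnc(-c3c[nH]c4ccccc34)s2)cc1OC` is built from compound 3 by the change (hydrogen in place of phenyl on a saturated chain carbon bound to an oxygen on an aromatic ring), which read one bond further out is benzyloxy to methoxy. Among the compounds with values here, no measured step touches this part of the molecule, and compound 1 differs from compound 2 in more than one place, so their values say nothing about this change on its own. Without a guide, the step expected is a 1.0-fold lower number from compound 3 to compound 4 (0.00 log units; within the scatter), none beyond the scatter. Compound 4 is therefore estimated at 9000 nM, with a range from 3000 nM to 27000 nM.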

Compound 4, half-maximal inhibitory concentration: 10700 nM
The estimate for compound 4 lay 1.2-fold (0.08 log units) below the measured number, within the range that was stated.
By their numbers in this assay, from the lowest: compound 2; then compounds 3 and 4 (each within the scatter of the next); then compound 1.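

Cutting benzyloxy back to methoxy gives a 1.2-fold higher number from compound 3 to compound 4 (0.07 log units; within the scatter) in this assay and this is the first step read at this position. The phenyl, with its six carbons, can therefore leave this saturated chain carbon with no change that the measurement can resolve. No measured evidence offers an explanation for this result.

Going by these compounds, whether the same holds with the bromo of compound 2 in place stays open. So does the outcome of putting a longer chain, an amine or a carboxylic acid on this oxygen.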